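Removing the phenoxy group from compound 3

This account rests on a few compounds, and the source may have more. Where it says the series, first, only, none or still open, it means among the compounds named here.

Going by the values given here, in a functional assay on HL-60 cells (Homo sapiens) for inhibition, read by resazurin assay, with a stated time of 72 h (a higher number here means a weaker inhibitor, a lower number a stronger inhibitor), compound 3 (`COc1ccc(C2C(Oc3ccccc3)C(=O)N2c2cc(OC)c(OC)c(OC)c2)cc1`) gives 19 nM as the lowest of the three numbers so far. Compound 1 (`COc1cc(N2C(=O)CC2c2ccc(SC)cc2)cc(OC)c1OC`) stands at 69 nM and compound 2 (`CCSc1ccc(C2CC(=O)N2c2cc(OC)c(OC)c(OC)c2)cc1`) at 204 nM in the same test.

The next change leads to compound 4 (`COc1ccc(C2CC(=O)N2c2cc(OC)c(OC)c(OC)c2)cc1`): hydrogen in place of phenoxy on a saturated ring carbon.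

Among the compounds with values here, no measured step covers this place. The only one, a 3.0-fold higher number from compound 1 to compound 2 (0.47 log units; beyond the scatter) for methyl in place of hydrogen on a saturated chain carbon bound to a sulfur, lies elsewhere and gives only a rough sense of scale. More useful are compound 1 at 69 nM and compound 2 at 204 nM as they lack the phenoxy group, as compound 4 does. Both also carry a sulfur group where compound 4 has methoxy, so the comparison is imperfect.

The estimated step in this assay is a 5.8-fold higher number from compound 3 to compound 4 (0.76 log units; beyond the scatter) towards a weaker inhibitor. For compound 4 the estimate is 110 nM with an expected range from 35 nM to 350 nM in this test.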

Compound 4, half-maximal inhibitory concentration: 76 nM
The estimate for compound 4 lay 1.4-fold (0.16 log units) above the measured number; measured number inside the range.
By their numbers in this assay, from the lowest: compound 3; then compounds 1 and 4 (each within the scatter of the next); then compound 2.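

Going by these compounds alone, the phenoxy group on the saturated ring carbon of the four-membered ring now has a measured contribution in this assay: its replacement by hydrogen gives a 4.0-fold higher number from compound 3 to compound 4 (0.60 log units; beyond the scatter), the only step at this position so far. On the aromatic carbon, methoxy and methylsulfanyl cannot be told apart, with a 1.1-fold higher number from compound 1 to compound 4 (0.04 log units; within the scatter), whereas methoxy in place of ethylsulfanyl gives a 2.7-fold lower number from compound 2 to compound 4 (0.43 log units; beyond the scatter) and so stays clear of the scatter. No measured evidence bears on the reason for any of these steps.

From the compounds shown here alone, whether a hydroxyl, a methoxy or an amine on this ring carbon would give a number close to that of compound 3 or to that of compound 4 remains open. Within the data shown here, also open is whether the phenoxy step carries over to a core with methylsulfanyl or ethylsulfanyl on the aromatic carbon, since only the pair with the 4-methoxyphenyl group covers it.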